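Cyano for methoxycarbonyl on the shared core

The source may report more compounds than this note shows. Statements on the series, on what has been measured and on what is new or still open speak of the compounds shown alone.

Measured in a functional assay on Hs 683 cells (Homo sapiens) for inhibition, read by MTT assay, with a stated time of 72 h; a higher number here means a weaker inhibitor of growth, a lower number a stronger inhibitor of growth:
- compound 1 `COC(=O)/C=C/C1=CC[C@H]2C(C)(C)CCC[C@]2(C)[C@H]1C=O`: 24000 nM
- compound 2 `CCOC(=O)/C(C)=C/C1=CC[C@H]2C(C)(C)CCC[C@]2(C)[C@H]1C=O`: 28000 nM
- compound 3 `COC(=O)/C=C/C=C/C1=CC[C@H]2C(C)(C)CCC[C@]2(C)[C@H]1C=O`: 12000 nM

Compound 1, at 24000 nM, holds the middle of the three numbers, and its steps to the other two stay within the scatter. Compound 4 `CC1(C)CCC[C@]2(C)[C@@H](C=O)C(/C=C/C#N)=CC[C@@H]12` carries cyano in place of methoxycarbonyl on a double-bonded chain carbon bound to a double-bonded chain carbon. Among the measured compounds shown here, no measured step makes this exchange. For the measured compounds named here, the only step at that place, a 2.0-fold lower number from compound 1 to compound 3 (0.30 log units; within the scatter), is a different change and lies within the scatter. No step beyond the scatter is therefore expected in this assay. The expected step is a 1.2-fold lower number from compound 1 to compound 4 (0.08 log units; within the scatter). For compound 4 the estimated value is 20000 nM, with an expected range of 9000 nM to 45000 nM.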

Compound 4, concentration for 50% growth inhibition: 28000 nM
Beside the measured number, compound 4's estimate is 1.4-fold (0.15 log units) below it, within the range that was stated.
By their numbers in this assay, from the lowest: compounds 3, 1, 2 and 4 (each within the scatter of the next, the first and the last beyond it).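

In this assay, cyano in place of methoxycarbonyl on a double-bonded chain carbon bound to a double-bonded chain carbon gives a 1.2-fold higher number from compound 1 to compound 4 (0.07 log units; within the scatter), so at this place the nitrile reads the same as the ester within the scatter. Cyano in place of 2-(methoxycarbonyl)ethenyl at the same place gives a 2.3-fold higher number from compound 3 to compound 4 (0.37 log units; beyond the scatter), the first modest step in the series beyond the scatter. No measurement bears on the cause of either step. Open, going by these compounds, is how a carboxylic acid, a primary amide or an amine at this place would read in this assay.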